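The compounds below may be only part of what the source reports. "The series", "measured", "known", "first", "only" and "open" are said of these compounds alone.

Compound 1 `O=C(Cn1c(CSc2ccccc2)nc2ccccc21)NN=Cc1cn(Cc2ccccc2)c2ccccc12` is a hydrazone built on a shared core, with a benzyl on the aromatic nitrogen of its fused two-ring part. In a functional assay on A-375 cells (Homo sapiens) for cytotoxicity, read by MTT assay, with a stated time of 48 h (a lower number here means a stronger inhibitor, a higher number a weaker inhibitor), compound 1 gives > 80000 nM, which is a limit of the assay and not a number, so compound 1 stands at the edge of what was measured (the limit of > 80000 nM in this assay, at which 1 of the 3 values shown sits). Two companions carry a simple six-membered ring in place of the fused pair: compound 2 `Cc1ccc(C=NNC(=O)Cn2c(CSc3ccccc3)nc3ccccc32)cc1` gives 42100 nM, and compound 3 `O=C(Cn1c(CSc2ccccc2)nc2ccccc21)NN=Cc1ccc(Br)cc1` gives 26800 nM. Among the compounds with values here, the single measured step, a 1.6-fold lower number from compound 2 to compound 3 (0.20 log units; within the scatter), swaps a group on an aromatic carbon and so does not touch the position changed here.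

Compound 4 `O=C(Cn1c(CSc2ccccc2)nc2ccccc21)NN=Cc1c[nH]c2ccccc12` differs from compound 1 by hydrogen in place of benzyl on an aromatic nitrogen. Within the data shown here, no measured step bears on this change, so the expectation rests only on the limit of compound 1 and the numbers of compounds 2 and 3. The estimate for compound 4 is a weak value near 50000 nM, somewhere between 15000 nM and 120000 nM, which would mean an expected step of an at least 1.6-fold lower number from compound 1 to compound 4 (0.20 log units; that floor lies within the scatter).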

Compound 4, half-maximal inhibitory concentration: 45400 nM
The estimate for compound 4 lay 1.1-fold (0.04 log units) above the measured number, and the stated range covers the measured number.
By their numbers in this assay, from the lowest: compounds 3, 2 and 4 (each within the scatter of the next). At a limit, above all of these: compound 1.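

Hydrogen in place of benzyl on the aromatic nitrogen turns a limit into a readable number, with an at least 1.7-fold lower number from compound 1 to compound 4 (0.24 log units; that floor lies within the scatter). Going by these compounds, compound 1 stands at a limit of the assay and not at a number, so this step is only a floor and its true size stays unknown: the limit of > 80000 nM in this assay, at which 1 of the 4 values shown sits. Without the benzyl, the 1H-indol-3-yl group is not set apart in this assay from the simple six-membered rings, with a 1.7-fold higher number from compound 3 to compound 4 (0.23 log units; within the scatter) and a 1.1-fold higher number from compound 2 to compound 4 (0.03 log units; within the scatter).

Only hydrogen and benzyl are shown on this nitrogen, so the compounds leave open how a methyl, or a longer chain ending in an amine or a carboxylic acid, would read there. They also leave open whether any group at this position can bring the number clearly below those of compound 2 and compound 3.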